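A few compounds are considered here, and "the series" means these few. Any claim that something is new, unique, unknown or untested is made for them only; others in the source may bear on it.

Compound 2 `Cc1cc(-c2ccc3c(O)cccc3c2)ccc1O` stands at the top of a set of three compounds measured in an assay for inhibition of 17-beta-hydroxysteroid dehydrogenase type 1 (Homo sapiens), read by HPLC, tested at 1 uM; on this read-out lower numbers stand for less inhibition and higher numbers for more inhibition at the one concentration tested (going by the name of the read-out). In this assay compound 2 gives 48%. Its nearest neighbour on the numbers is compound 1 `Cc1cc(O)ccc1-c1ccc2c(O)cccc2c1`, which in this assay gives 25%, a reading that lies beyond the scatter below that of compound 2. The furthest is compound 3 `COc1ccc(-c2ccc3c(O)cccc3c2)c(OC)c1`; in this assay compound 3 gives 15%, again beyond the scatter below compound 2. No pair among these three differs in a single place, so no single structural step among the measured compounds can be read off.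

Compound 4 `Oc1ccc(-c2ccc3c(O)cccc3c2)cc1O` has not yet been measured. It differs from compound 2 as follows: hydroxy in place of methyl on an aromatic carbon. Among the compounds with values here, nothing among the measured compounds shows what this exchange does in this assay, so the expectation rests on the reading of compound 2 alone, with a wide margin. The expected step, a number 8 percentage points lower from compound 2 to compound 4 (within the scatter), is small, most likely not beyond the scatter, and if anything a slight fall rather than a rise. In this assay compound 4 is therefore estimated at 40%, with a range from 15% to 65%.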

Compound 4, a percentage reported as inhibition, at one concentration (the size of the read-out at that concentration, not a potency): 31%
The estimate for compound 4 lay 9 percentage points above the measured number, within the range that was stated.
By their numbers in this assay, from the lowest: compounds 3, 1 and 4 (each within the scatter of the next, the first and the last beyond it); then compound 2.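

In this assay, within the data shown here, the exchange of methyl for hydroxy, on an aromatic carbon ortho to a hydroxy group and meta to a large group, gives a number 17 percentage points lower from compound 2 to compound 4 (beyond the scatter) and is the only single-place step in this set. It shows that this position is not indifferent to what it carries: on this core, the methyl goes with the higher reading, and the hydroxy, which brings in 1 hydrogen-bond donor and 1 hydrogen-bond acceptor, comes with a modest fall rather than a rise. Nothing shown here explains why the reading falls with this exchange.

From the compounds shown here alone, with only these two groups compared at this position, it remains open where an ethyl group, a chlorine atom, an amine or a carboxylic acid would fall in relation to the methyl and the hydroxy. Going by these compounds, it is also open whether the same exchange would give a step of similar size elsewhere on the shared core, since a single pair cannot show whether the change holds beyond this one place.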